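Methyl to methoxyphenyl on a pyrazolopyridine side chain

The compounds below may be only part of what the source reports. "The series", "measured", "known", "first", "only" and "open" are said of these compounds alone.

Of the compounds shown here, three have been measured in a functional assay on THP-1 cells (Homo sapiens) for cytotoxicity, tested at 10 uM; a lower number here means less inhibition, a higher number more inhibition at the concentration tested (going by the name of the read-out). Compound 1 `Cc1nn(C)c2ncc(CCCO)cc12` gives 7%, compound 2 `COC[C@H](O)[C@@H](OC)[C@@H](OC)C1=CC2C(C)=NN(C)C2N=C1` gives 5%, and compound 3 `CCO[C@@H](C1=CC2C(C)=NN(c3ccccc3)C2N=C1)[C@H](OC)[C@@H](O)COC` gives 4%; the three numbers lie within the usual scatter of one another, so none can be called apart from the others. Compound 4 `CCO[C@@H](C1=CC2C(c3ccc(OC)cc3)=NN(c3ccccc3)C2N=C1)[C@H](OC)[C@@H](O)COC` has not been measured. It differs from compound 3 in one place: 4-methoxyphenyl in place of methyl on a carbon with a double bond to nitrogen. Among the measured compounds shown here, no measured pair shows this change, so its size is unknown. Because compound 3 gives 4% and the other two sit close by, the step of a number 4 percentage points higher from compound 3 to compound 4 (within the scatter) is expected to stay within the scatter, with at most a small rise. Compound 4 is estimated at 8%, between 0% and 25%.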

Compound 4, a percentage reported as inhibition, at one concentration (the size of the read-out at that concentration, not a potency): 6%
Compound 4: the middle estimate sits 2 percentage points above what was measured; the range from low to high includes it.
By their numbers in this assay, from the lowest: compounds 3, 2, 4 and 1 (each within the scatter of the next).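

In this assay the swap of methyl for 4-methoxyphenyl on a carbon with a double bond to nitrogen reads as a number 2 percentage points higher from compound 3 to compound 4 (within the scatter). Among the compounds shown here, this gives the first reading at this position, which accepts a group of 8 heavy atoms, including a six-membered aromatic ring, in place of a single carbon with no change that can be told from scatter. No available evidence bears on the reason for this result. As far as these compounds go, it remains open whether an unsubstituted phenyl, an amine or a carboxylic acid on this carbon would give a similar number.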